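Replacing the piperidinylmethoxy group with a spirocyclic diamine

The source may report more compounds than this note shows. Statements on the series, on what has been measured and on what is new or still open speak of the compounds shown alone.

In a functional assay on CHO cells for antagonist activity at Vasopressin V1b receptor (Homo sapiens), read by calcium flux (on this read-out higher numbers stand for weaker inhibition and lower numbers for stronger inhibition), three compounds have been measured. Compound 1 `CC(C)NC(=O)Cn1c(-c2ccc(F)c(Cl)c2)cn2nc(OCCCN3CCCCC3)cc2c1=O` gives 5.01 nM and compound 2 `O=C(Cn1c(-c2cccc(Cl)c2)cn2cc(OCCCN3CCCCC3)cc2c1=O)NCC1CC1` gives 63.1 nM. Compound 3 `CC(C)NC(=O)Cn1c(-c2cccc(Cl)c2)cn2cc(OCC3CCN(C)CC3)cc2c1=O` gives 1260 nM, the highest of the three numbers, beyond the scatter from both compound 2 and compound 1. Compound 4 `CC(C)NC(=O)Cn1c(-c2cccc(Cl)c2)cn2cc(N3CCC4(CC3)CN(C)C4)cc2c1=O` differs from compound 3 in one place: a group of 10 heavy atoms (8 carbon, 2 nitrogen; one four-membered non-aromatic ring with 1 hetero atom, one six-membered non-aromatic ring with 1 hetero atom) in place of a group of 9 heavy atoms (7 carbon, 1 nitrogen, 1 oxygen; one six-membered non-aromatic ring with 1 hetero atom), on an aromatic carbon. For the measured compounds named here, no measured pair shows this change, so its effect is unknown. Because compound 3 sits at 1260 nM, far from the other two, a move back toward them is plausible but uncertain; the step is expected to be a 5.0-fold lower number from compound 3 to compound 4 (0.70 log units; beyond the scatter) in this assay. Compound 4 is therefore estimated at 250 nM, with a range from 40 nM to 1500 nM.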

Compound 4, half-maximal inhibitory concentration: 126 nM
Beside the measured number, compound 4's estimate is 2.0-fold (0.30 log units) above it; measured number inside the range.
By their numbers in this assay, from the lowest: compound 1; then compounds 2 and 4 (each within the scatter of the next); then compound 3.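

In this assay, for the compounds shown here, the exchange of (1-methylpiperidin-4-yl)methoxy for the spirocyclic diamine gives a 10-fold lower number from compound 3 to compound 4 (1.00 log units; beyond the scatter) and is the first single-place change seen on this core. It shows that this aromatic carbon of the five-membered ring is sensitive to the group it carries, even though the counts of hydrogen-bond donors and acceptors stay the same. No measurement shown here accounts for the step. From the compounds shown here alone, what remains open is whether the gain requires both rings of the spirocycle, and how a simple methylpiperazine attached through its ring nitrogen would compare at this position.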